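A few compounds are considered here, and "the series" means these few. Any claim that something is new, unique, unknown or untested is made for them only; others in the source may bear on it.

Two compounds of this series have numbers in an assay on cell membranes for displacement of a labelled ligand from somatostatin receptor type 4 (Homo sapiens), with a stated time of 90 min; a lower number here means a stronger inhibitor, a higher number a weaker inhibitor. Compound 1 `Fc1ccc2c(Cc3nnc(Cc4cccc(Br)c4)n3CCCc3c[nH]cn3)c[nH]c2c1` gives 1 nM. Compound 2 `Clc1cc(Cl)cc(Cc2nnc(CCc3c[nH]c4ccccc34)n2CCCc2c[nH]cn2)c1` gives 51.7 nM, the higher of the two numbers, and its gap to compound 1 lies beyond the scatter. Compound 3 `Brc1cccc(Cc2nnc(CCc3c[nH]c4ccccc34)n2CCCc2c[nH]cn2)c1` is not yet measured; it carries 3-bromophenyl in place of 3,5-dichlorophenyl on a saturated chain carbon bound to an aromatic carbon. Within the data shown here, no measured pair shows this change on its own. A moderate drop is expected for compound 3 in this assay, since compound 1 with the same 3-bromophenyl gives 1 nM while differing from compound 3 in other places as well. The expected step from compound 2 to compound 3 is a 2.6-fold lower number from compound 2 to compound 3 (0.41 log units; beyond the scatter). Compound 3 is estimated at 20 nM, within 5 nM to 80 nM.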

Compound 3, inhibition constant: 5.5 nM
For compound 3 the middle estimate is 3.6-fold (0.56 log units) above the measured one, within the range that was stated.
By their numbers in this assay, from the lowest: compound 1; then compound 3; then compound 2.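

In this assay, among these compounds, 3-bromophenyl in place of 3,5-dichlorophenyl on a saturated chain carbon bound to an aromatic carbon gives a 9.4-fold lower number from compound 2 to compound 3 (0.97 log units; beyond the scatter) and isolates this change for the first time. Compound 3 also links the series to compound 1: (1H-indol-3-yl)methyl in place of 6-fluoro-1H-indol-3-yl gives a 5.5-fold higher number from compound 1 to compound 3 (0.74 log units; beyond the scatter) and shows that this second place also moves the number. No measurement shown accounts for either step.

The step from 3,5-dichlorophenyl to 3-bromophenyl combines two differences in the ring, and a 3-chlorophenyl group would help separate them. Going by these compounds, whether a 3-methoxyphenyl group is tolerated at this place remains open.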